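The source may report more compounds than this note shows. Statements on the series, on what has been measured and on what is new or still open speak of the compounds shown alone.

Working notes on the step from compound 1 to compound 4.

In a functional assay on a cell-free system (Platelet, plasma, Homo sapiens) for inhibition (on this read-out higher numbers stand for weaker inhibition and lower numbers for stronger inhibition), compound 1 `Cc1ccc(N(CCN2CCC(OCC(=O)O)CC2)C(=O)c2ccc(C(F)(F)F)cc2)cc1` gives > 10000 nM as a limit and not a number. Compound 2 `Cc1ccc(N(CCN2CCC(OCC(=O)O)CC2)C(=O)c2ccc(-c3ccccc3)cc2)cc1` gives > 10000 nM which is also a limit. Compound 3 `O=C(O)COC1CCN(CCN(C(=O)c2ccc(C(F)(F)F)cc2)c2ccc(Cl)cc2)CC1` gives > 10000 nM which is a limit as well. For the measured compounds named here, the series so far therefore has no numeric value, only the limit of > 10000 nM in this assay, at which 3 of the 3 values shown sit, to go on.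

Compound 4 `COc1cc(OC)cc(C(=O)N(CCN2CCC(OCC(=O)O)CC2)c2ccc(C)cc2)c1` has 3,5-dimethoxyphenyl in place of 4-(trifluoromethyl)phenyl on a carbonyl carbon, and the full count is 3,5-dimethoxyphenyl in place of 4-(trifluoromethyl)phenyl on a carbonyl carbon for this change.

The measured steps that bear on it are a step that the two limits leave unreadable from compound 1 to compound 2 at the same aryl group and a step that the two limits leave unreadable from compound 1 to compound 3 elsewhere on the molecule. Going by the values given here, neither has a size that can be read, so no step of definite size or direction is expected in this assay for this change.

The expected step is a step that the limit leaves unreadable from compound 1 to compound 4 as a rough estimate only. For compound 4 the estimated value is 12000 nM with an expected range from 3000 nM to 40000 nM and a report as a limit remains the likeliest outcome.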

Compound 4, half-maximal inhibitory concentration: 530 nM
Compound 4: middle estimate off by 23-fold (1.35 log units), on the high side; the whole stated range lies above it.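

In this assay, the aryl group on the carbonyl carbon proves able to take the series off its limit, with 3,5-dimethoxyphenyl in place of 4-(trifluoromethyl)phenyl giving an at least 18-fold lower number from compound 1 to compound 4 (1.27 log units; beyond the scatter). For the compounds shown here, the earlier steps, phenyl in place of trifluoromethyl and chloro in place of methyl, cannot be read, so this is the first change with a definite direction. Compound 4 thus supplies the first numeric value, while the other compounds remain at a limit: the limit of > 10000 nM in this assay, at which 3 of the 4 values shown sit.

Still open, going by these compounds, is whether the change depends on both methoxy groups or would survive with a single methoxy group, or with an amine or a hydroxyl group in their place. Also open, on these data alone, is whether chloro in place of methyl on an aromatic carbon of compound 4 would keep a numeric value.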